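Cytotoxicity of piperidine sulfonamides sharing one core

The source may hold more compounds than are shown below. What is called first, only, known or untested is meant among the compounds shown, and "the series" means these compounds.

Measured so far:
- compound 1, `CC1CCN(S(=O)(=O)c2ccc(NC(=O)c3ccc([N+](=O)[O-])o3)cc2)CC1`: in an ADME assay on IMR-90 cells (Homo sapiens) for cytotoxicity, read by CellTiter-Blue, with a stated time of 46 h (on this read-out lower numbers stand for an effect already at smaller amounts and higher numbers for an effect only at larger amounts of compound), compound 1 gives > 25000 nM, a limit of the assay.
- compound 2, `CC(C)(C)C1CCN(S(=O)(=O)c2ccc(NC(=O)c3ccc([N+](=O)[O-])o3)cc2)CC1`: in this assay compound 2 gives > 25000 nM, a limit of the assay.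
- compound 3, `O=C(Nc1ccc(S(=O)(=O)N2CCC3(CCCCC3)CC2)cc1)c1ccc([N+](=O)[O-])o1`: in this assay compound 3 gives > 25000 nM, a limit of the assay.

Compound 2 stands at the limit of this assay, and so do the two other measured compounds: the limit of > 25000 nM in this assay, at which 3 of the 3 values shown sit. Within the data shown here, the only step between measured compounds that differ in one place, a step that the two limits leave unreadable from compound 1 to compound 2, is therefore not readable in size or direction.

Compound 4, `O=C(Nc1ccc(S(=O)(=O)N2CCC(Cl)CC2)cc1)c1ccc([N+](=O)[O-])o1`, is still to be measured in this assay. It differs from compound 2 in one place: chloro in place of tert-butyl on a saturated ring carbon. Among the measured compounds shown here, no readable step bears on this change, and every value so far is a limit. The expectation for compound 4 in this assay is accordingly another limit, with a step that the limit leaves unreadable from compound 2 to compound 4 expected to show no step beyond the scatter. The estimate for compound 4 in this assay is 30000 nM, within 10000 nM to 100000 nM.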

Compound 4, half-maximal effective concentration: > 25000 nM
Compound 4 ended at the assay's limit; the forecaster's own chance of this, stated with the estimate: 80%; the middle value is on the limit's open side.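

No step can be read between compound 4 and either compound 1 or compound 2, because all of them sit at one limit: the limit of > 25000 nM in this assay, at which 4 of the 4 values shown sit.

The compounds shown leave open at what concentration, if any, a group at this ring carbon produces a measurable effect in this assay.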